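Fluoro for methyl on the pendant aryl ring

The source may hold more compounds than are shown below. What is called first, only, known or untested is meant among the compounds shown, and "the series" means these compounds.

Compound 1 `Cc1ccc(-n2nc(C(=O)Nc3ccc(Oc4ncnc5ccsc45)cc3)c(C)cc2=O)cc1` and compound 2 `Cc1cc(=O)n(-c2ccc(F)cc2)nc1C(=O)Nc1ccc(Oc2ncnc3ccsc23)cc1` share one core and differ in a single place (fluoro in place of methyl on an aromatic carbon). In a functional assay on HepG2 cells (Homo sapiens) for cytotoxicity, read by MTT assay, with a stated time of 72 h (a higher number here means a weaker inhibitor, a lower number a stronger inhibitor), compound 1 gives 25000 nM, while compound 2 gives 2110 nM, a change of a 12-fold lower number from compound 1 to compound 2 (1.07 log units; beyond the scatter). Compound 3 `Cc1ccc(-n2nc(C(=O)Nc3ccc(Oc4ncnc5sccc45)c(F)c3)c(C)cc2=O)cc1` carries a second core; the difference between the two cores is not broken down here. In this assay compound 3 returns only a limit, > 40000 nM, and a limit of this kind is the one cited at the limit of > 40000 nM in this assay, at which 1 of the 3 values shown sits.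

Compound 4 `Cc1cc(=O)n(-c2ccc(F)cc2)nc1C(=O)Nc1ccc(Oc2ncnc3sccc23)c(F)c1` is not yet measured and stands to compound 3 as compound 2 stands to compound 1, the same change made on the second core (fluoro in place of methyl on an aromatic carbon). The expected step is an at least 6.6-fold lower number from compound 3 to compound 4 (0.82 log units; beyond the scatter), which rests on the measured change from compound 1 to compound 2 of a 12-fold lower number from compound 1 to compound 2 (1.07 log units; beyond the scatter) and on the fact that compound 3 gives only a limit, so the starting point is not pinned down. Compound 4 is thus expected to reach about 6000 nM, somewhere between 1500 nM and 40000 nM.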

Compound 4, half-maximal inhibitory concentration: 12500 nM
Compound 4: middle estimate off by 2.1-fold (0.32 log units), on the low side; the range from low to high includes it.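

On the second core, the change from 4-methylphenyl to 4-fluorophenyl gives an at least 3.2-fold lower number from compound 3 to compound 4 (0.50 log units; beyond the scatter) in this assay, so the direction seen on the first core, a 12-fold lower number from compound 1 to compound 2 (1.07 log units; beyond the scatter), holds in both pairs of this series. This shows that the direction carries across these two cores, but it does not show that the size carries with it, and the two steps compare only as follows: the same change on two cores in this assay, a 12-fold lower number (1.07 log units; beyond the scatter) from compound 1 to compound 2 and an at least 3.2-fold lower number (0.50 log units; beyond the scatter) from compound 3 to compound 4; the limit leaves it open whether they differ The value of compound 3 is a limit and not a number: the limit of > 40000 nM in this assay, at which 1 of the 4 values shown sits.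

Among these compounds, with only two matched pairs, the direction rests on compounds 1 to 4 and says nothing about any further core, and what separates the two cores is not broken down. As far as these compounds go, only methyl and fluoro appear at this place on the pendant ring, so it remains open how chloro, methoxy or an amine there would read in this assay.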